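Nitro in place of dimethylamino: an expected step

The source may hold more compounds than are shown below. What is called first, only, known or untested is meant among the compounds shown, and "the series" means these compounds.

Measured so far in a functional assay on U-937 cells (Homo sapiens) for antiproliferative activity, with a stated time of 48 h (a higher number here means that more compound is needed for the effect, a lower number that less compound is needed), for the two compounds:
- compound 1 `N#Cc1ccc(NC(=O)CCCCCCC(=O)NO)cc1` gives 7000 nM
- compound 2 `CN(C)c1ccc(NC(=O)CCCCCCC(=O)NO)cc1` gives 1700 nM

Of these two, compound 2 at 1700 nM holds the lower number. Compound 3 `O=C(CCCCCCC(=O)Nc1ccc([N+](=O)[O-])cc1)NO` has not yet been measured. It departs from compound 2 by nitro in place of dimethylamino on an aromatic carbon in one change: nitro in place of dimethylamino on an aromatic carbon. Within the data shown here, only one measured step bears on this change, and it is modest but beyond the scatter: a 4.1-fold lower number from compound 1 to compound 2 (0.61 log units; beyond the scatter) with dimethylamino in place of cyano on an aromatic carbon. Among the measured compounds shown here, no measured compound carries nitro, so this is indirect evidence. With dimethylamino leaving again, a step of similar or somewhat smaller size toward a higher number is expected in this assay for compound 3. The estimated step is a 2.6-fold higher number from compound 2 to compound 3 (0.42 log units; beyond the scatter) in this reading. For compound 3 the expected value is 4500 nM within an estimated range of 1500 nM to 12000 nM overall.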

Compound 3, half-maximal effective concentration: 22000 nM
For compound 3 the middle estimate is 4.9-fold (0.69 log units) below the measured one; the whole stated range lies below it.
By their numbers in this assay, from the lowest: compound 2; then compound 1; then compound 3.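

In this assay, nitro in place of dimethylamino on the aromatic carbon gives a 13-fold higher number from compound 2 to compound 3 (1.11 log units; beyond the scatter), a large step and wider than the one earlier step at this place had shown. Nitro and cyano also do not sit at the same level, since the change from cyano to nitro gives a 3.1-fold higher number from compound 1 to compound 3 (0.50 log units; beyond the scatter), a modest step but one beyond the scatter. The group on this carbon therefore separates all three compounds, with dimethylamino giving the lowest number, cyano the middle one and nitro the highest.

Nothing available explains why the numbers fall in this order. Going by these compounds, whether a simple amino group or a methoxy group on the same carbon would fall nearer compound 2 or compound 3 stays open, as does how a longer chain would change the numbers.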